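A few compounds are considered here, and "the series" means these few. Any claim that something is new, unique, unknown or untested is made for them only; others in the source may bear on it.

In an assay on LM cells for displacement of a labelled ligand from Neuropeptide Y receptor type 5 (Homo sapiens) (on this read-out higher numbers stand for weaker inhibition and lower numbers for stronger inhibition), the measured compounds are: compound 1 `Fc1ccc(C2(c3ccc(F)cc3)CNC(c3cccc(C(F)(F)F)c3)=N2)cc1` with 6.2 nM; compound 2 `Fc1ccc(C2(c3ccc(F)cc3)CNC(c3ccc(C(F)(F)F)cc3)=N2)cc1` with 160 nM; compound 3 `CC(=O)c1cccc(C2=NC(c3ccc(F)cc3)(c3ccc(F)cc3)CN2)c1` with 44 nM.

Among the compounds with values here, compound 3 holds the second highest of the three numbers, nearer to compound 2 than to compound 1, and the only measured step that reaches it is a 7.1-fold higher number from compound 1 to compound 3 (0.85 log units; beyond the scatter), a modest one. Compound 4 `Fc1ccc(C2(c3ccc(F)cc3)CNC(c3cccnc3)=N2)cc1` differs from compound 3 by pyridin-3-yl in place of 3-acetylphenyl on a carbon with a double bond to nitrogen. Within the data shown here, that measured step is the sole one at this position and it was modest; no measured pair removes the substituent altogether or exchanges a ring carbon for nitrogen, so the direction is uncertain. The step is therefore expected to be a 2.7-fold higher number from compound 3 to compound 4 (0.44 log units; beyond the scatter). Compound 4 is estimated at 120 nM, within a range from 25 nM to 600 nM.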

Compound 4, half-maximal inhibitory concentration: 7.2 nM
Beside the measured number, compound 4's estimate is 17-fold (1.22 log units) above it; the whole stated range lies above it.
By their numbers in this assay, from the lowest: compounds 1 and 4 (each within the scatter of the next); then compound 3; then compound 2.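

In this assay, a 6.1-fold lower number from compound 3 to compound 4 (0.79 log units; beyond the scatter) shows that this carbon with a double bond to nitrogen does not need a substituted phenyl ring. Pyridin-3-yl, with no substituent on its ring, gives a number within the scatter of compound 1, whereas the earlier compounds had only substituted phenyl rings here. Nothing measured here bears on why the number falls. Going by these compounds, what a plain phenyl ring would give, and so whether the ring nitrogen or the loss of the acetyl carries this step, stays open. On these data alone, the outcome with pyridin-4-yl, or with an amine on the pyridine ring, also stays open.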